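The source may report more compounds than this note shows. Statements on the series, on what has been measured and on what is new or still open speak of the compounds shown alone.

Measured so far:
- compound 1 `O=S(=O)(/C=C/c1ncccc1Cl)c1ccc(F)cc1` — 231 nM
- compound 2 `O=S(=O)(/C=C/c1ncccc1Cl)c1ccc(Cl)cc1` — 65 nM

In an assay on U2OS cells for activation of nuclear factor erythroid 2-related factor 2 (Homo sapiens), read by beta-arrestin recruitment, with a stated time of 6 h (a higher number here means that more compound is needed for the effect, a lower number that less compound is needed), compound 2 gives the lower of the two numbers seen; its nearest neighbour is compound 1, and the change a 3.6-fold lower number from compound 1 to compound 2 (0.55 log units; beyond the scatter) lies beyond the scatter. Compound 3 `O=S(=O)(/C=C\c1ncccc1Cl)c1ccc(Cl)cc1` differs from compound 2 as follows: the two compounds have the same atoms and bonds and differ only in configuration as drawn: 1 of 1 stereo elements differ; a double bond is drawn E in compound 2 and Z in compound 3. The only measured step swaps a halogen on the aryl ring and says nothing about the geometry of the double bond, so no shown step bears directly on this change. Without a measured precedent, he treats the outcome as open and leans toward a weaker number, since the whole shape of the molecule is redrawn. He therefore expects a step of a 3.1-fold higher number from compound 2 to compound 3 (0.49 log units; beyond the scatter) in this assay from compound 2 to compound 3, with wide uncertainty. Compound 3 is estimated at 200 nM in this assay, between 50 nM and 900 nM.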

Compound 3, half-maximal effective concentration: 1750 nM
For compound 3 the middle estimate is 8.8-fold (0.94 log units) below the measured one; measured number above the stated range.
By their numbers in this assay, from the lowest: compound 2; then compound 1; then compound 3.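

Changing only the geometry of the double bond gives a 27-fold higher number from compound 2 to compound 3 (1.43 log units; beyond the scatter) in this assay, and this step is larger than the one seen for the halogen swap, a 3.6-fold lower number from compound 1 to compound 2 (0.55 log units; beyond the scatter) in the same assay. The earlier pair showed that the halogen on the aryl ring matters; this pair shows that the E arrangement of the double bond matters more in the compounds shown. The loss can be assigned to the configuration alone because nothing else changes: the fact that compounds 2 and 3 differ only in the configuration as drawn.

The compounds shown leave open whether the same gap between E and Z would hold with fluoro in place of chloro on the aryl ring, since only one such pair is shown. They also leave open how a methoxy group or a nitrile would fare in place of that halogen, or a carbonyl in place of the sulfonyl group.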